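A few compounds are considered here, and "the series" means these few. Any claim that something is new, unique, unknown or untested is made for them only; others in the source may bear on it.

Measured in an in vitro ADME assay on microsomes from liver (Rattus norvegicus) for metabolic stability; on this read-out lower numbers stand for slow clearance and higher numbers for fast clearance:
compound 1 `CCN(CC)C(=O)[C@H]1CC[C@@H](n2/c(=N/C(=O)c3ccccc3)[nH]c3ccc(CN4CCCCC4)cc32)CC1` gives 682 mL.min-1.g-1
compound 2 `COC(=O)[C@H]1CC[C@@H](n2/c(=N/C(=O)c3ccccc3)[nH]c3ccc(CN4CCCCC4)cc32)CC1` gives 459 mL.min-1.g-1
compound 3 `CC(C)NC(=O)[C@H]1CC[C@@H](n2/c(=N/C(=O)c3ccc(F)c(Cl)c3)[nH]c3ccc(CN4CCC(C(C)(C)O)CC4)cc32)CC1` gives 44 mL.min-1.g-1

Compound 2 holds the second highest of the three numbers in this assay. Its nearest neighbour is compound 1, which gives 682 mL.min-1.g-1, a gap within the scatter; the farthest is compound 3, which gives 44 mL.min-1.g-1, a gap beyond the scatter. Compound 4 `CC(C)NC(=O)[C@H]1CC[C@@H](n2/c(=N/C(=O)c3ccccc3)[nH]c3ccc(CN4CCCCC4)cc32)CC1`, not yet measured, differs from compound 2 in one place: isopropylamino in place of methoxy on a carbonyl carbon.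

Among the measured compounds shown here, only one measured step bears on this change, the exchange at the same carbonyl carbon: a 1.5-fold lower number from compound 1 to compound 2 (0.17 log units; within the scatter). That step, diethylamino against methoxy, stayed within the scatter. Compound 3 also carries isopropylamino, but it differs from compound 2 in several further places, so its low number cannot be laid at the door of the amide alone.

An exchange of the group on the carbonyl carbon is therefore expected to move this assay little. For compound 4 the step is estimated as a 1.1-fold lower number from compound 2 to compound 4 (0.06 log units; within the scatter), so compound 4 is expected to give 400 mL.min-1.g-1, within a range from 180 mL.min-1.g-1 to 850 mL.min-1.g-1.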

Compound 4, intrinsic clearance in microsomes: 389 mL.min-1.g-1
For compound 4 the middle estimate is 1.0-fold (0.01 log units) above the measured one, within the range that was stated.
By their numbers in this assay, from the lowest: compound 3; then compounds 4, 2 and 1 (each within the scatter of the next).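

In this assay, the exchange of methoxy for isopropylamino on the carbonyl carbon gives a 1.2-fold lower number from compound 2 to compound 4 (0.07 log units; within the scatter), and the exchange of diethylamino for isopropylamino gives a 1.8-fold lower number from compound 1 to compound 4 (0.24 log units; within the scatter). Among the compounds shown here, three groups at this place now stand within the scatter of one another, where the earlier compounds offered only a single step. That includes isopropylamino, which carries a hydrogen-bond donor that methoxy lacks, so among compounds 1, 2 and 4 neither that donor nor the larger group separates the numbers, and no measurement at hand offers an explanation.

As far as these compounds go, whether a carboxylic acid or a morpholine amide on this carbonyl carbon would also stay within the scatter remains open. So does which of the several differences between compound 3 and compound 4 accounts for the number of compound 3.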